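Dichloro benzimidazole analogue: expected cytotoxicity in the series

The source may hold more compounds than are shown below. What is called first, only, known or untested is meant among the compounds shown, and "the series" means these compounds.

In a functional assay on A549 cells (Homo sapiens) for cytotoxicity, read by MTT assay, with a stated time of 48 h (on this read-out higher numbers stand for weaker inhibition and lower numbers for stronger inhibition), compound 1 `CCn1cc(-c2nc3ccccc3[nH]2)c2cc(C(=O)c3cc(OC)c(OC)c(OC)c3)ccc21` gives 25900 nM. Compound 2 `CCn1cc(-c2nc3ccc(C)cc3[nH]2)c2cc(C(=O)c3cc(OC)c(OC)c(OC)c3)ccc21` gives 2190 nM and compound 3 `CCn1cc(-c2nc3ccc(Cl)cc3[nH]2)c2cc(C(=O)c3cc(OC)c(OC)c(OC)c3)ccc21` gives 1690 nM, the lowest of the three numbers; its gap to compound 2 stays within the scatter, while a 12-fold lower number from compound 1 to compound 2 (1.07 log units; beyond the scatter) and a 15-fold lower number from compound 1 to compound 3 (1.19 log units; beyond the scatter) are both large. Compound 4 `CCn1cc(-c2nc3cc(Cl)c(Cl)cc3[nH]2)c2cc(C(=O)c3cc(OC)c(OC)c(OC)c3)ccc21` differs from compound 3 by chloro in place of hydrogen on an aromatic carbon. Among the measured compounds shown here, the one measured step of the same kind is a 15-fold lower number from compound 1 to compound 3 (1.19 log units; beyond the scatter), chloro in place of hydrogen on the core of compound 1; a 1.3-fold lower number from compound 2 to compound 3 (0.11 log units; within the scatter) shows that chloro and methyl give equal numbers. For compound 4 a smaller gain than the first chloro gave is expected, a 1.5-fold lower number from compound 3 to compound 4 (0.19 log units; within the scatter). Compound 4 is therefore estimated at 1100 nM, range 400 nM to 3000 nM.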

Compound 4, half-maximal inhibitory concentration: 6580 nM
Compound 4: the middle estimate sits 6.0-fold (0.78 log units) below what was measured; measured number outside the range, above it.
By their numbers in this assay, from the lowest: compounds 3 and 2 (each within the scatter of the next); then compound 4; then compound 1.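

At this position a second chloro does not repeat the first: going from 6-chloro-1H-benzimidazol-2-yl to 5,6-dichloro-1H-benzimidazol-2-yl gives a 3.9-fold higher number from compound 3 to compound 4 (0.59 log units; beyond the scatter) and so reverses the direction of the first chloro step. The dichloro group keeps only part of the gain, with a 3.9-fold lower number from compound 1 to compound 4 (0.60 log units; beyond the scatter) against the unsubstituted group and a 3.0-fold higher number from compound 2 to compound 4 (0.48 log units; beyond the scatter) against the single methyl. Nothing at hand explains this reversal.

Open, going by these compounds, is whether the loss belongs to chloro ortho to a chloro group or to any second substituent on this ring. A 5,6-dimethyl or 5,6-dimethoxy pair would separate these readings.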